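Chloro in Place of Methoxy on the Benzyl Group

This account rests on a few compounds, and the source may have more. Where it says the series, first, only, none or still open, it means among the compounds named here.

Measured compounds:
compound 1 `COc1ccc(Cn2cc(/C=N\NC(=O)c3c[nH]c4ccccc34)c3ccccc32)cc1`: 41600 nM
compound 2 `COc1ccc(Cn2cc(/C=N\NC(=O)c3c[nH]c4ccccc34)c3cc(OC)ccc32)cc1`: 30500 nM
compound 3 `COc1ccc(Cn2cc(/C=N\NC(=O)c3c[nH]c4ccc(Br)cc34)c3cc(OC)ccc32)cc1`: 44500 nM

In a functional assay on MIA PaCa-2 cells (Homo sapiens) for cytotoxicity (a lower number here means a stronger inhibitor, a higher number a weaker inhibitor), compound 3 has the highest of the three numbers, but its nearest neighbour, compound 1, and its furthest, compound 2, both lie within the usual scatter of it, so the three measured compounds cannot be told apart on potency. Compound 4 `COc1ccc2c(c1)c(/C=N\NC(=O)c1c[nH]c3ccc(Br)cc13)cn2Cc1ccc(Cl)cc1` has not yet been measured; it differs from compound 3 in one place: chloro in place of methoxy on an aromatic carbon. The two measured steps each replace one substituent on an aromatic carbon elsewhere in the shared core: a 1.4-fold lower number from compound 1 to compound 2 (0.13 log units; within the scatter) and a 1.5-fold higher number from compound 2 to compound 3 (0.16 log units; within the scatter). Neither moved the number beyond the scatter. For the measured compounds named here, no measured step touches the 4-methoxybenzyl group itself, so the new change rests on no direct precedent, but the pattern so far is of small single-substituent swaps leaving this assay largely unchanged. Compound 4 is therefore expected to give 40000 nM, in the range 18000 nM to 90000 nM, a step of a 1.1-fold lower number from compound 3 to compound 4 (0.05 log units; within the scatter) that is estimated to stay within the scatter.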

Compound 4, half-maximal inhibitory concentration: 26300 nM
Estimate against measurement, compound 4: 1.5-fold (0.18 log units) above; low and high end bracket the measured number.
By their numbers in this assay, from the lowest: compounds 4, 2, 1 and 3 (each within the scatter of the next).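

This is the first change shown on the 4-methoxybenzyl group itself: in this assay, going to 4-chlorobenzyl gives a 1.7-fold lower number from compound 3 to compound 4 (0.23 log units; within the scatter), so this position behaves like the two places changed earlier, and the swap does not separate the two compounds. Chloro also brings no hydrogen-bond acceptor where methoxy brought one, yet the number stays within the scatter, so the acceptor at this place is not shown to matter in this assay. No independent data bear on this result.

On these data alone, whether an amine or a carboxylic acid at this place would move the number beyond the scatter remains open. Also open, as far as these compounds go, is whether the same swap would behave alike on a core without the bromo.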